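Shortening the chain and trimming the amide

This account rests on a few compounds, and the source may have more. Where it says the series, first, only, none or still open, it means among the compounds named here.

Compound 1 `CC(C)(C)C(=O)NCCCN1CCN(c2ccc(Cl)cc2)CC1`: 200 nM
Compound 2 `CC(C)(C)C(=O)NCCCCCN1CCN(c2ccc(Cl)cc2)CC1`: 126 nM

Both compounds share the same core and differ only in the chain that carries the amide. In an assay on HEK293 cells for binding affinity to D(4) dopamine receptor (Homo sapiens), read by radioligand binding (on this read-out higher numbers stand for weaker inhibition and lower numbers for stronger inhibition), compound 1 gives 200 nM, and compound 2 gives 126 nM, the lower of the two numbers, yet within the scatter of the first. Compound 3 `CC(C)C(=O)NCCCCN1CCN(c2ccc(Cl)cc2)CC1` is not yet measured. Against compound 2 its change is (isopropylcarbonyl)amino in place of (((tert-butyl)carbonyl)amino)methyl on a saturated chain carbon, four bonds along the chain from an amine nitrogen in a ring. Going by the values given here, no measured pair isolates such a change, so no step beyond the scatter is expected in this assay in either direction. Compound 3 is estimated at 150 nM, with a range from 60 nM to 400 nM. The expected step is a 1.2-fold higher number from compound 2 to compound 3 (0.08 log units; within the scatter).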

Compound 3, inhibition constant: 126 nM
Estimate against measurement, compound 3: 1.2-fold (0.08 log units) above; the measured number falls inside the stated range.
By their numbers in this assay, from the lowest: compounds 2, 3 and 1 (each within the scatter of the next).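

Going by these compounds alone, at this place on the chain, (isopropylcarbonyl)amino in place of (((tert-butyl)carbonyl)amino)methyl gives no change at the digits printed from compound 2 to compound 3 (within the scatter) in this assay and so offers the first measured comparison of these two amide ends. Likewise, ((isopropylcarbonyl)amino)methyl in place of ((tert-butyl)carbonyl)amino gives a 1.6-fold lower number from compound 1 to compound 3 (0.20 log units; within the scatter) so neither change moves the number beyond the scatter. No measurement available here explains this result.

Each step alters the chain and the amide end together, so neither can be judged alone. On these data alone, a longer chain, or an amine in place of the amide, remains open.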